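A few compounds are considered here, and "the series" means these few. Any claim that something is new, unique, unknown or untested is made for them only; others in the source may bear on it.

Compound 1 `COc1ccccc1Oc1ccc2c(NCCCNCc3ccco3)ccnc2c1` belongs to a small group of close relatives that share one core and differ only in the group attached to it. In a physicochemical assay for acid dissociation, compound 1 gives 9.28. Compound 2 `COc1cccc(CNCCCNc2ccnc3cc(Oc4ccc(Cl)cc4)ccc23)c1O` gives 9.28 in this assay, and compound 3 `COc1ccc(Oc2ccc3c(NCCCNCc4cccc(OC)c4O)ccnc3c2)cc1` gives 9.28. Compound 1 therefore sits level with compound 2 and compound 3 at the digits shown, with no difference beyond the scatter in either direction. Going by the values given here, the one measured step between neighbours, no change at the digits printed from compound 2 to compound 3 (within the scatter), shows that swapping one small group for another on the distant aromatic ring left the read-out untouched.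

Compound 4 `c1coc(CNCCCNc2ccnc3cc(C4CCCCC4)ccc23)c1` has not yet been measured. The change from compound 1 is cyclohexyl in place of 2-methoxyphenoxy on an aromatic carbon. This removes a ring bearing two oxygen atoms and puts a saturated carbon ring in its place, at a site far from the chain that carries the amines. Among the compounds with values here, the only measured step of a comparable kind, from compound 2 to compound 3, moved nothing; no measured step touches this exact exchange.

The step expected from compound 1 to compound 4 is therefore a number 0.02 log units higher from compound 1 to compound 4 (within the scatter), none beyond the scatter. Compound 4 is estimated to give 9.3 in this assay, within 9 to 9.6.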

Compound 4, acid dissociation constant: 9.47
Beside the measured number, compound 4's estimate is 0.17 log units below it; the measured number falls inside the stated range.
By their numbers in this assay, from the lowest: compounds 1, 2, 3 and 4 (each within the scatter of the next).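

Exchanging the whole 2-methoxyphenoxy group for cyclohexyl on this aromatic carbon gives, in this assay, a number 0.19 log units higher from compound 1 to compound 4 (within the scatter) and so does not separate the two compounds. The earlier step, no change at the digits printed from compound 2 to compound 3 (within the scatter), replaced only chloro with methoxy on the outer ring, whereas this exchange replaces the whole group attached to the shared core: an aromatic ring and its oxygen atoms leave, and a non-aromatic ring of carbon only enters. The read-out therefore stays within the scatter for a much larger change at this place than any seen before, although nothing available here explains that result.

These compounds leave open whether a group of a different kind on this same aromatic carbon, such as an amine or a carboxylic acid, would also stay within the scatter in this assay. As far as these compounds go, it is also open whether changes closer to the amines, such as a longer chain in place of the one that carries them, would shift this read-out beyond the scatter.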